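Pyridine to thiophene swap on the aminomethyl side chain

A few compounds are considered here, and "the series" means these few. Any claim that something is new, unique, unknown or untested is made for them only; others in the source may bear on it.

Measured so far:
compound 1, `Nc1nc(NCc2cccs2)nc2sc(-c3ccco3)nc12`: 75 nM
compound 2, `Nc1nc(NCc2cccnc2)nc2sc(-c3ccco3)nc12`: 109 nM

In a functional assay on CHO cells for agonist activity at adenosine receptor A2b (Homo sapiens), read by scintillation counting and cAMP accumulation, with a stated time of 150 min, in the presence of a further agent that is not named here (on this read-out higher numbers stand for weaker inhibition and lower numbers for stronger inhibition), compound 1 gives 75 nM. In this assay compound 2 gives 109 nM, the highest of the two numbers; its nearest neighbour is compound 1, and the step of a 1.5-fold higher number from compound 1 to compound 2 (0.16 log units; within the scatter) lies within the scatter. Compound 3, `Nc1nc(NCc2ccsc2)nc2sc(-c3ccco3)nc12`, has not yet been measured. It differs from compound 2 by thiophen-3-yl in place of pyridin-3-yl on a saturated chain carbon bound to a nitrogen on an aromatic ring. Going by the values given here, the only measured step that bears on this change is a 1.5-fold higher number from compound 1 to compound 2 (0.16 log units; within the scatter), in which thiophen-2-yl was replaced by pyridin-3-yl at the same place and the number hardly moved. The step to compound 3 reverses that exchange, with the sulfur ring attached at its 3-position rather than its 2-position. Among the compounds with values here, since the one measured step on this side chain stayed within the scatter, no change beyond the scatter is expected in this assay for compound 3 either, with the number estimated to sit at or slightly under that of compound 2, a 1.3-fold lower number from compound 2 to compound 3 (0.11 log units; within the scatter). The estimate for compound 3 is 85 nM, within a range of 35 nM to 200 nM.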

Compound 3, half-maximal inhibitory concentration: 8.96 nM
Beside the measured number, compound 3's estimate is 9.5-fold (0.98 log units) above it; the whole stated range lies above it.
By their numbers in this assay, from the lowest: compound 3; then compounds 1 and 2 (each within the scatter of the next).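

In this assay, the group on a saturated chain carbon bound to a nitrogen on an aromatic ring turns out to be able to shift the number well beyond the scatter, with a 12-fold lower number from compound 2 to compound 3 (1.09 log units; beyond the scatter) when thiophen-3-yl takes the place of pyridin-3-yl, although the earlier exchange at this place had stayed within it. Having a sulfur ring here is not enough on its own, since compound 1 also carries one and there is still an 8.4-fold lower number from compound 1 to compound 3 (0.92 log units; beyond the scatter) on going from thiophen-2-yl to thiophen-3-yl, so among these three compounds the thiophen-3-yl group alone stands apart, with compound 3 lowest by steps beyond the scatter to both others. Nothing at hand accounts for the size of these two steps.

The compounds shown leave open whether the low number belongs to thiophen-3-yl in particular or would also appear with furan-3-yl or a plain phenyl ring at this place. They also leave open whether it would hold with a longer chain, such as ethyl, linking the ring to the nitrogen, or with another group in place of the furan-2-yl on the shared core.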